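Halogen Swap on a Shared Core in a Rat Toxicity Read-Out

A few compounds are considered here, and "the series" means these few. Any claim that something is new, unique, unknown or untested is made for them only; others in the source may bear on it.

Measured so far:
compound 1, `Clc1ccc(OCC2=NCCO2)cc1`: 20%
compound 2, `Brc1ccccc1OCC1=NCCO1`: 20%
compound 3, `Clc1ccccc1OCC1=NCCO1`: 30%

All three were tested in a toxicity assay on the whole organism with Rattus norvegicus as the target, at a dose of 200 mg/kg by the oral route; on this read-out higher numbers stand for a stronger effect at the one dose given and lower numbers for a weaker effect. Compound 3 and compound 2 differ in one place, (bromo in place of chloro on an aromatic carbon), and the step of a number 10 percentage points lower from compound 3 to compound 2 (within the scatter). Compound 1 and compound 3 have the same atoms joined differently; the difference between the two cores is not broken down here. Compound 1 is level with compound 2 at the digits given, and compound 1 and compound 3 lie within the scatter of each other, so no order among the three can be read.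

Compound 4, `Brc1ccc(OCC2=NCCO2)cc1`, is not yet measured. It differs from compound 1 in one place, (bromo in place of chloro on an aromatic carbon). This is the same kind of change as that from compound 3 to compound 2, though the surroundings differ: there the change sits ortho to a group of 7 heavy atoms, here para to a group of 7 heavy atoms.

Compound 4 is expected to show a step of a number 2 percentage points lower from compound 1 to compound 4 (within the scatter) in this assay, resting on compound 1 at 20% and on the earlier step being within the scatter. The estimate for compound 4 is 18%, with a range from 5% to 35%.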

Compound 4, a percentage reported as activity, at one dose (the size of the read-out at that dose, not a potency): 10%
For compound 4 the middle estimate is 8 percentage points above the measured one; measured number inside the range.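

In this assay, bromo in place of chloro on an aromatic carbon gives a number 10 percentage points lower from compound 1 to compound 4 (within the scatter). Set beside the same change on the other core, the result carries over with no difference that can be told apart: the same change on two cores in this assay, a number 10 percentage points lower (within the scatter) from compound 3 to compound 2 and a number 10 percentage points lower (within the scatter) from compound 1 to compound 4, 0 percentage points apart, within the scatter of two such steps. This shows only that, on both cores, the swap stays within the ordinary spread of such measurements, so the agreement is one of two small steps and does not establish that bromo gives a truly lower number than chloro on either core, nor that any real effect travels from one core to the other.

The compounds shown carry only chloro or bromo on the aromatic carbon, which leaves open whether a group such as methoxy, a nitrile or an amine in that place would move the read-out beyond the scatter. They also leave open whether a longer chain joining the aromatic ring to the rest of the molecule would alter the picture.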